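The source may hold more compounds than are shown below. What is called first, only, known or untested is meant among the compounds shown, and "the series" means these compounds.

Compound 1 `COc1cc(Cl)cc(-c2nn(-c3cccc(NC(=O)Nc4cc(C(F)(F)F)cc(C(F)(F)F)c4)c3)cc2-c2ccncc2)c1`: 101%
Compound 2 `COc1cc(Cl)cc(-c2nn(-c3cccc(NC(=O)Nc4ccc(Cl)c(Cl)c4)c3)cc2-c2ccncc2)c1`: 96%

The two measured compounds were tested in a functional assay on NCI-H226 cells (Homo sapiens) for inhibition, read by sulforhodamine B assay, with a stated time of 48 h, tested at 0.01 uM; a lower number here means a stronger effect, a higher number a weaker effect of the compound at the concentration tested. In this assay compound 1 gives 101%, and compound 2 gives 96%. Compound 2 stands with the lowest of the two numbers, but its nearest neighbour, compound 1, lies only a few points higher, a gap within the scatter, so the two values show no difference that can be relied on. Both values sit near the level at which the cells are untouched. Among the compounds with values here, no pair of measured compounds differing in one place is given, so no measured step is available.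

Compound 3 `COc1cc(Cl)cc(-c2nn(-c3cccc(NC(=O)Nc4cccc(C(F)(F)F)c4)c3)cc2-c2ccncc2)c1` differs from compound 2 in one place: 3-(trifluoromethyl)phenyl in place of 3,4-dichlorophenyl on an amide-type nitrogen. Since compound 1 and compound 2 carry different groups on that nitrogen and still give values within the scatter of each other, this exchange is not expected to move the number beyond the scatter either. Compound 3 is therefore estimated to give 98%, with a range from 87% to 108%. The expected a number 2 percentage points higher from compound 2 to compound 3 (within the scatter) lies within the scatter.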

Compound 3, a percentage reported as activity, at one concentration (the size of the read-out at that concentration, not a potency): 95%
For compound 3 the middle estimate is 3 percentage points above the measured one; low and high end bracket the measured number.
By their numbers in this assay, from the lowest: compounds 3, 2 and 1 (each within the scatter of the next).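

In this assay, within the data shown here, the first measured steps at the amide-type nitrogen show no effect that can be told from the scatter: 3-(trifluoromethyl)phenyl in place of 3,4-dichlorophenyl gives a number 1 percentage points lower from compound 2 to compound 3 (within the scatter), and hydrogen in place of trifluoromethyl on an aromatic carbon gives a number 6 percentage points lower from compound 1 to compound 3 (within the scatter). The second step adds something the first two compounds could not show, as it alters a single substituent on the aryl group rather than exchanging the whole group, and even this leaves compound 3 at 95%, near the level at which the cells are untouched. With three different aryl groups on this nitrogen now within the scatter of one another at this one low concentration, the result gives no handle on this position, and no measurement here offers an explanation for it.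

Going by these compounds, whether an amine or a carboxylic acid on this aryl group, or a longer chain in its place on the amide-type nitrogen, would move the number beyond the scatter remains open. Also open, on these data alone, is whether compounds 1, 2 and 3 would separate at a higher concentration, since a single concentration at which all three stay near the untouched level cannot rank them.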